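This account rests on a few compounds, and the source may have more. Where it says the series, first, only, none or still open, it means among the compounds named here.

Measured so far:
compound 1, `CC1(C)C[C@H](CN([C@H](CCC(F)(F)F)C(N)=O)S(=O)(=O)c2ccc(Cl)cc2)O1`, in a physicochemical assay for lipophilicity, read by HPLC, measured as octanol-water partition, at pH 7.4 (on this read-out higher numbers stand for higher lipophilicity and lower numbers for lower lipophilicity), gives 3.8
compound 2, `NC(=O)[C@@H](CCC(F)(F)F)N(C[C@@H]1CCCO1)S(=O)(=O)c1ccc(Cl)cc1`, in this assay gives 3.5

Compound 1 stands highest of the two numbers; compound 2 is nearest, and the step of a number 0.30 log units lower from compound 1 to compound 2 (within the scatter) lies within the scatter. Compound 3, `NC(=O)[C@@H](CCC(F)(F)F)N(C[C@H]1CCO1)S(=O)(=O)c1ccc(Cl)cc1`, is not yet measured. It differs from compound 1 as follows: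

oxetan-2-yl in place of 4,4-dimethyloxetan-2-yl on a saturated chain carbon bound to a sulfonamide nitrogen

Among the compounds with values here, the one measured step bearing on this change is a number 0.30 log units lower from compound 1 to compound 2 (within the scatter), where the same group on the same saturated chain carbon is replaced by oxolan-2-yl. Oxetan-2-yl is a smaller replacement than oxolan-2-yl by the count given, so for compound 3 a downward step at least as large as that one, and probably somewhat larger, is expected, though whether it clears the scatter is uncertain. The step expected for compound 3 is a number 0.70 log units lower from compound 1 to compound 3 (beyond the scatter). For compound 3 the estimate in this assay is 3.1, with a range from 2.7 to 3.5.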

Compound 3, distribution coefficient: 2.6
Compound 3: middle estimate off by 0.50 log units, on the high side; the whole stated range lies above it.
By their numbers in this assay, from the lowest: compound 3; then compounds 2 and 1 (each within the scatter of the next).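

In this assay, this place on the saturated chain carbon bound to a sulfonamide nitrogen proves sensitive to the choice of ring: removing the two methyl groups from the 4,4-dimethyloxetan-2-yl group gives a number 1.20 log units lower from compound 1 to compound 3 (beyond the scatter), whereas the oxolan-2-yl replacement alone had not cleared the scatter. Oxetan-2-yl in place of oxolan-2-yl gives a number 0.90 log units lower from compound 2 to compound 3 (beyond the scatter), so oxetan-2-yl stands apart from both larger groups, which remain indistinguishable from each other. No measurement at hand accounts for the size of these steps.

The compounds shown leave open how an azetidin-2-yl ring, with an amine in place of the ring oxygen, or an open methoxyethyl chain would read at this place. They also leave open whether a single methyl group on the oxetan-2-yl ring would read with compound 3 or with compound 1.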